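A few compounds are considered here, and "the series" means these few. Any claim that something is new, unique, unknown or untested is made for them only; others in the source may bear on it.

Measured in a functional assay on MDA-MB-231 cells (Homo sapiens) for inhibition, read by sulforhodamine B assay, with a stated time of 72 h; a higher number here means a weaker inhibitor of growth, a lower number a stronger inhibitor of growth:
compound 1 `NNC(=O)CCc1ccncc1-c1ccc2ccccc2c1`: > 10000 nM (a limit)
compound 2 `CNC(=O)/C=C/c1ccncc1-c1ccc2cc[nH]c2c1`: 7680 nM
compound 3 `CCOC(=O)/C=C/c1ccncc1-c1ccc2[nH]ccc2c1`: > 10000 nM (a limit)

Compound 1 has no number, only a limit, and it stands at the limit of > 10000 nM in this assay, at which 2 of the 3 values shown sit. Going by the values given here, compound 2 gives 7680 nM, the only true number so far.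

Compound 4 `CNC(=O)CCc1ccncc1-c1ccc2ccccc2c1` keeps the core of compound 1 and changes one place only: methyl in place of amino on an amide-type nitrogen. In words, this is methyl in place of amino on an amide-type nitrogen, so aminocarbamoyl becomes methylcarbamoyl. Among the compounds with values here, no pair of measured compounds differs in one place alone, so the series gives no direct reading of this change in this assay.

The expectation is therefore for no step beyond the usual scatter, with neither direction favoured, and compound 4 may well end at the same limit as compound 1. This rests on the weak growth inhibition across the series, where even compound 2 reaches only 7680 nM. The expected change is a step that the limit leaves unreadable from compound 1 to compound 4. For compound 4 the estimated value is 12000 nM, with an expected range of 5000 nM to 30000 nM.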

Compound 4, concentration for 50% growth inhibition: 8980 nM
Beside the measured number, compound 4's estimate is 1.3-fold (0.13 log units) above it; the range from low to high includes it.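

Methyl in place of amino on an amide-type nitrogen gives the first step in this assay between compounds that differ in one place, and it reads an at least 1.1-fold lower number from compound 1 to compound 4 (0.04 log units; that floor lies within the scatter) without showing a change beyond the scatter. Only this floor can be read, because compound 1 stands at a limit and not at a number: the limit of > 10000 nM in this assay, at which 2 of the 4 values shown sit. Going by these compounds alone, compound 4 gives 8980 nM as a true number, which places a value on the core of compound 1 for the first time and makes the methylcarbamoyl group a measured reference point on that core.

Open, from the compounds shown here alone, is the true size of the step from aminocarbamoyl to methylcarbamoyl, and with it whether the swap of amino for methyl does anything beyond the scatter in this assay at all. Also open, going by these compounds, is how this amide-type nitrogen responds to other groups on the same core, such as an ethyl group, a longer alkyl chain or a hydroxyl group in place of the methyl, or a carboxylic acid in place of the whole methylcarbamoyl group.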